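Trifluoromethylphenyl in Place of Methylphenyl on the Thiazole Carbon

A few compounds are considered here, and "the series" means these few. Any claim that something is new, unique, unknown or untested is made for them only; others in the source may bear on it.

Three compounds share a common core and differ only in the aryl group carried on the five-membered ring. Compound 1 `Cc1nc(-c2cccc3ccccc23)sc1COc1ccc2c(c1)OCC2CC(=O)O` bears a naphthalen-1-yl group, compound 2 `Cc1ccccc1-c1nc(C)c(COc2ccc3c(c2)OCC3CC(=O)O)s1` a 2-methylphenyl group, and compound 3 `Cc1ccc(-c2nc(C)c(COc3ccc4c(c3)OCC4CC(=O)O)s2)cc1` a 4-methylphenyl group. In a functional assay on CHO cells for agonist activity at Free fatty acid receptor 1 (Homo sapiens), read by FLIPR and calcium flux, tested at 100 nM (a lower number here means a weaker effect, a higher number a stronger effect of the compound at the concentration tested), compound 1 gives 8.53%, compound 2 gives 10.7%, and compound 3 gives 54.9%. Compound 3 stands highest of the three, with the step of a number 44.2 percentage points higher from compound 2 to compound 3 (beyond the scatter) and the step of a number 46.4 percentage points higher from compound 1 to compound 3 (beyond the scatter), while the step of a number 2.2 percentage points higher from compound 1 to compound 2 (within the scatter) separates the two weaker compounds.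

Compound 4 `Cc1nc(-c2cccc(C(F)(F)F)c2)sc1COc1ccc2c(c1)OCC2CC(=O)O` is the next member, reached by the change (3-(trifluoromethyl)phenyl in place of 4-methylphenyl on an aromatic carbon). Among the measured compounds shown here, no measured step involves a trifluoromethyl group; the one that bears most on it is a number 44.2 percentage points higher from compound 2 to compound 3 (beyond the scatter), which shows that moving a methyl group between two positions of the phenyl ring shifts this assay by a large amount, so changing both group and position is expected to matter. Compound 4 is therefore estimated to give 30% (range 8% to 58%), a step of a number 24.9 percentage points lower from compound 3 to compound 4 (beyond the scatter) expected downward from compound 3.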

Compound 4, a percentage reported as activity, at one concentration (the size of the read-out at that concentration, not a potency): 35.7%
Estimate against measurement, compound 4: 5.7 percentage points below; the measured number falls inside the stated range.
By their numbers in this assay, from the lowest: compounds 1 and 2 (each within the scatter of the next); then compound 4; then compound 3.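

The aryl position on the thiazole carbon accepts a larger group than methyl and still gives a clear response in this assay: 3-(trifluoromethyl)phenyl stands well clear of the two weakest compounds, with a number 25 percentage points higher from compound 2 to compound 4 (beyond the scatter) and a number 27.2 percentage points higher from compound 1 to compound 4 (beyond the scatter). It does not match 4-methylphenyl, however, with a number 19.2 percentage points lower from compound 3 to compound 4 (beyond the scatter), so among the four compounds the response falls into three levels rather than two, and compound 4 occupies the middle. Nothing available here accounts for this order of the aryl groups.

This change alters both the group and its place on the phenyl ring. 3-methylphenyl and 4-(trifluoromethyl)phenyl would be needed to separate the two contributions. Going by these compounds, how an amine or a longer chain on that phenyl ring would fare also remains open.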